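The compounds below may be only part of what the source reports. "The series", "measured", "known", "first", "only" and "open" are said of these compounds alone.

Measured compounds:
- compound 1, `COc1ccc(-c2cc(/C=C/C(=O)c3ccc(N)cc3)[nH]n2)cc1`: -3%
- compound 2, `COc1cc(-c2cc(/C=C/C(=O)c3ccc(Cl)c(Cl)c3)[nH]n2)cc(OC)c1OC`: 62%

Both compounds were tested in a functional assay on SK-MEL-5 cells (Homo sapiens) for cytotoxicity, read by sulforhodamine B assay, with a stated time of 48 h, tested at 10 uM; a lower number here means a stronger effect, a higher number a weaker effect of the compound at the concentration tested. Compound 1 gives -3% in this assay, while compound 2 gives 62%. Of the two numbers available, compound 2 stands at the higher one, and its gap to compound 1 is well beyond the usual scatter of repeated measurements, so compound 2 shows the weaker effect of the two at the concentration tested.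

The next compound, compound 3, `COc1cc(-c2cc(/C=C/C(=O)c3ccc(F)c(F)c3)[nH]n2)cc(OC)c1OC`, has not been measured yet. It is drawn from compound 2 by one change: 3,4-difluorophenyl in place of 3,4-dichlorophenyl on a carbonyl carbon. The carbonyl carbon and everything else in the shared core stay as they are.

Among the measured compounds shown here, no measured pair in this set differs in just one place, so there is no comparable step to lean on. The expectation is a step from compound 2 to compound 3 of about a number 8 percentage points higher from compound 2 to compound 3 (within the scatter), a small shift upward that would not clearly exceed the scatter. On that basis compound 3 is estimated at 70%, with a likely range from 45% to 95%.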

Compound 3, a percentage reported as activity, at one concentration (the size of the read-out at that concentration, not a potency): -21%
The estimate for compound 3 lay 91 percentage points above the measured number; the measured number lies below the stated range.
By their numbers in this assay, from the lowest: compound 3; then compound 1; then compound 2.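

In this assay the exchange of 3,4-dichlorophenyl for 3,4-difluorophenyl on a carbonyl carbon gives a number 83 percentage points lower from compound 2 to compound 3 (beyond the scatter) and so turns a weaker effect into a clearly stronger one at the concentration tested. Among the compounds shown here, this is the first direct comparison in the set, and it shows that this position is far from indifferent to what it carries. The two groups match in heavy atom count, in their six-membered aromatic ring of carbon only and in having no hydrogen-bond donors or acceptors and no net charge, so the large step goes with the exchange of chlorine for fluorine, although nothing available here explains why.

The compounds shown leave open how a ring carrying bromine atoms, a trifluoromethyl group or a nitrile would read at this position, and whether such compounds would fall nearer compound 2 or compound 3. From the compounds shown here alone, it also remains open whether the same exchange of chlorine for fluorine would produce a step of similar size on the core of compound 1, which carries one methoxy group rather than three.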